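The source may report more compounds than this note shows. Statements on the series, on what has been measured and on what is new or still open speak of the compounds shown alone.

Working notes on the series. Of the compounds shown here, three have been measured in an assay on isolated protein for inhibition of aldehyde dehydrogenase 1A1 (Homo sapiens), read by spectrophotometry, tested at 10 uM; a lower number here means less inhibition, a higher number more inhibition at the concentration tested (going by the name of the read-out). Compound 1 `CCc1ccc(C(=O)N2CCN(Cc3nc4ccccc4n3Cc3cccc(C)c3)CC2)cc1` gives 67% and stands second highest of the three numbers. Compound 2 `Cc1cccc(Cn2c(OC3CCN(C(=O)C4CC4)CC3)nc3ccccc32)c1` gives 80.6%, a number above compound 1 by a gap beyond the usual scatter. Compound 3 `O=C(C1CC1)N1CCN(Cc2nc3ccccc3n2Cc2ccccc2)CC1` gives 23.9%, the lowest of the three and beyond the scatter below compound 1. Among the measured compounds shown here, no two measured compounds differ in a single place, so no measured step is available to calibrate the change considered next.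

Compound 4 `COc1ccc(C(=O)N2CCN(Cc3nc4ccccc4n3Cc3cccc(C)c3)CC2)cc1` is not yet measured in this assay. It differs from compound 1 in one place: methoxy in place of ethyl on an aromatic carbon. The leaving and entering groups carry the same heavy-atom count, both without a ring, and the entering group brings one hydrogen-bond acceptor; the change sits on an aromatic carbon of a six-membered aromatic ring of carbon only.

For the measured compounds named here, the series holds no measured pair of this kind, so the expectation rests on compound 1 and on the small size of the exchange. The expected step, a number 7 percentage points lower from compound 1 to compound 4 (within the scatter), is small and downward, with the likely outcome within the scatter of compound 1. Compound 4 is expected to give 60%, in a range from 40% to 78%.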

Compound 4, a percentage reported as inhibition, at one concentration (the size of the read-out at that concentration, not a potency): 55.5%
The estimate for compound 4 lay 4.5 percentage points above the measured number, within the range that was stated.
By their numbers in this assay, from the lowest: compound 3; then compound 4; then compound 1; then compound 2.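

In this assay, among the compounds shown here, methoxy in place of ethyl on an aromatic carbon, para to a large group, gives a number 11.5 percentage points lower from compound 1 to compound 4 (beyond the scatter) and so supplies the first measured single-place step. The position is therefore not indifferent to this exchange, even though the leaving and entering groups carry the same heavy-atom count and neither has a ring. Compound 4 gives 55.5% and thus keeps a clear part of the inhibition at the concentration tested, while no measurement available here bears on what lies behind the step.

The compounds shown leave open how other groups on this aromatic carbon would read, such as a hydroxyl, a chlorine, a dimethylamino group, a carboxylic acid or a longer chain such as propyl, so one pair cannot yet separate the effect of the entering oxygen from that of removing the ethyl carbons. They also leave open whether the same exchange gives a step of similar size and direction when the rest of compound 1 is changed, and how the two compounds compare in potency rather than at a single concentration.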